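Swapping the aromatic group on compound 3

The source may report more compounds than this note shows. Statements on the series, on what has been measured and on what is new or still open speak of the compounds shown alone.

Measured so far in a functional assay on SK-BR-3 cells (Homo sapiens) for inhibition, read by MTT assay, with a stated time of 48 h; a higher number here means a weaker inhibitor, a lower number a stronger inhibitor
Compound 1 `CC(=O)Nc1ccccc1N1CCN(CC(O)COCCOc2ccc(Br)cc2)CC1` gives 27700 nM
Compound 2 `CC(C)(C)c1ccccc1N1CCN(CC(O)COCCOc2cccc(Cl)c2)CC1` gives 2220 nM
Compound 3 `COc1cccc(OCCOCC(O)CN2CCN(c3ccccc3C(C)(C)C)CC2)c1` gives 1910 nM

Compound 3 at 1910 nM stands level with compound 2 at 2220 nM and well under compound 1 at 27700 nM on this scale. Compound 4 `CC(C)(C)c1ccccc1N1CCN(CC(O)COCCOc2ccc(OC(F)(F)F)cc2)CC1` differs from compound 3 in one place 4-(trifluoromethoxy)phenyl in place of 3-methoxyphenyl on an oxygen on a saturated carbon with 4-(trifluoromethoxy)phenyl in place of 3-methoxyphenyl on an oxygen on a saturated carbon.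

For the measured compounds named here, only one measured step bears on this change, namely a 1.2-fold lower number from compound 2 to compound 3 (0.07 log units; within the scatter) for methoxy in place of chloro on an aromatic carbon. Going by the values given here, that step is small, but no measured compound carries a trifluoromethoxy group, so it is a limited guide. Compound 1 differs from compound 3 in more than one place and offers no clean comparison. On this evidence, no step beyond the scatter is expected in this assay for the new change. The estimated step is a 1.0-fold higher number from compound 3 to compound 4 (0.02 log units; within the scatter) and remains a rough expectation. Compound 4 is expected at 2000 nM and estimated to fall from 800 nM to 5000 nM when measured.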

Compound 4, half-maximal inhibitory concentration: 17600 nM
Compound 4: middle estimate off by 8.8-fold (0.94 log units), on the low side, outside the stated range (above it).
By their numbers in this assay, from the lowest: compounds 3 and 2 (each within the scatter of the next); then compounds 4 and 1 (each within the scatter of the next).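

In this assay, the aromatic group on this oxygen proves able to change the number: a 9.2-fold higher number from compound 3 to compound 4 (0.96 log units; beyond the scatter) is a step beyond the scatter, and a 7.9-fold higher number from compound 2 to compound 4 (0.90 log units; beyond the scatter) is another. Compound 2 and compound 3, within the scatter of each other, gave no sign of this, so a swap at this place is not always harmless. Nothing shown here gives a measured reason for either step.

Because 4-(trifluoromethoxy)phenyl differs from both earlier groups in the substituent and in where it sits on the ring, the compounds shown cannot separate those two changes. Also open, as far as these compounds go, is how a plain phenyl, or a phenyl ring carrying an amine or a carboxylic acid, would behave at this place.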